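The source may report more compounds than this note shows. Statements on the series, on what has been measured and on what is new or still open speak of the compounds shown alone.

The series shares a common core. Compound 1 is `Nc1cc(F)ccc1NC(=O)c1ccc(COc2ccccc2)cc1`. Compound 2 is `CCCc1ccc(OCc2ccc(C(=O)Nc3ccccc3N)cc2)cc1`. Compound 3 is `Nc1cnccc1NC(=O)/C=C/c1ccc(COc2ccccc2)cc1`. Compound 4, not yet measured, is `CCc1ccc(OCc2ccc(C(=O)Nc3ccccc3N)cc2)cc1`.

In a functional assay on MGC-803 cells (Homo sapiens) for antiproliferative activity, read by CCK-8 assay, with a stated time of 72 h (a higher number here means a weaker inhibitor, a lower number a stronger inhibitor), compound 1 gives 6020 nM. In this assay compound 2 gives 4420 nM. The two numbers for compound 1 and compound 2 lie within the scatter of each other, so neither is ranked above the other. Compound 3 in this assay gives > 32000 nM, which is a limit of the assay rather than a number; compound 3 sits at the limit of > 32000 nM in this assay, at which 1 of the 3 values shown sits.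

Compound 2 thus holds the lowest of the two plain numbers, with compound 1 nearest to it and within the scatter.

The step from compound 2 to compound 4 is hydrogen in place of methyl on a saturated chain carbon, two bonds along the chain from an aromatic carbon. The change shortens the chain at the saturated chain carbon two bonds along the chain from an aromatic carbon. Within the data shown here, no pair of measured compounds differing only at that site is available, so the expectation rests on the small size of the change. In this assay the step from compound 2 to compound 4 is expected to be a 1.1-fold higher number from compound 2 to compound 4 (0.05 log units; within the scatter), no larger than the scatter, in either direction. Compound 4 is estimated at 5000 nM in this assay, with a range from 2500 nM to 10000 nM.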

Compound 4, half-maximal inhibitory concentration: 5880 nM
Beside the measured number, compound 4's estimate is 1.2-fold (0.07 log units) below it; measured number inside the range.
By their numbers in this assay, from the lowest: compounds 2, 4 and 1 (each within the scatter of the next). At a limit, above all of these: compound 3.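

In this assay, the series now holds one pair that differs in one place, and it reads a 1.3-fold higher number from compound 2 to compound 4 (0.12 log units; within the scatter) for the change from 4-propylphenyl to 4-ethylphenyl. Among these compounds, the chain can therefore lose this one carbon, on a saturated chain carbon two bonds along the chain from an aromatic carbon, with no step beyond the scatter, and compound 2 and compound 4 are not ranked against each other; the earlier compounds gave no reading at this site. Nothing measured here bears on this result.

As far as these compounds go, two chain lengths on one core say little about the wider range at this site: it remains open whether a butyl chain, a methyl group or a hydrogen in place of the propyl chain, or an amine or a carboxylic acid carried on the chain, would stay within the scatter of compound 2. From the compounds shown here alone, it is also open whether the same shortening would read alike on the core of compound 1 or on that of compound 3.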